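Thiophene for Tolyl on a Long-Chain Sulfonamide

The source may hold more compounds than are shown below. What is called first, only, known or untested is meant among the compounds shown, and "the series" means these compounds.

Three compounds were measured in a functional assay on MCF7 cells (Homo sapiens) for cytotoxicity, read by MTT assay, with a stated time of 48 h; on this read-out lower numbers stand for stronger inhibition and higher numbers for weaker inhibition:
compound 1, `CCCCCCCCCCCCNC(=O)[C@@H](NS(=O)(=O)c1ccc(C)cc1)[C@@H](C)O`, gave 31100 nM;
compound 2, `CCCCCCCCCCCCNC(=O)[C@@H](NS(=O)(=O)c1cccs1)[C@@H](C)O`, gave 19100 nM;
compound 3, `CCCCCCCCCCCCCCCCCCNC(=O)[C@@H](NS(=O)(=O)c1ccc(C)cc1)[C@@H](C)O`, gave 60100 nM.

Compound 2 differs from compound 1 by thiophen-2-yl in place of 4-methylphenyl on a sulfonyl sulfur, and that change gave a 1.6-fold lower number from compound 1 to compound 2 (0.21 log units; within the scatter). Compound 3 differs from compound 1 by hexyl in place of hydrogen on a saturated chain carbon, ten or more bonds along the chain from an amide-type nitrogen, a change that gave a 1.9-fold higher number from compound 1 to compound 3 (0.29 log units; within the scatter). Compound 4, `CCCCCCCCCCCCCCCCCCNC(=O)[C@@H](NS(=O)(=O)c1cccs1)[C@@H](C)O`, has not yet been measured in this assay. Going by the values given here, it differs from compound 3 by thiophen-2-yl in place of 4-methylphenyl on a sulfonyl sulfur, so the change from compound 3 to compound 4 is the same change as the one from compound 1 to compound 2, made on the core of compound 3 rather than the core of compound 1. Since compound 1 and compound 2 differ by a step within the scatter, the step from compound 3 to compound 4 is expected to be of similar size, a 1.6-fold lower number from compound 3 to compound 4 (0.20 log units; within the scatter). Compound 4 is therefore estimated at 38000 nM in this assay, with a range from 20000 nM to 80000 nM.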

Compound 4, half-maximal inhibitory concentration: > 200000 nM
Compound 4 ended at the assay's limit; the forecaster's own chance of this, stated with the estimate: 5%; middle value at least 5.2-fold (0.72 log units) from the limit.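

Compound 4 gave > 200000 nM in this assay, which is a limit of the assay and not a number. Read against that limit, thiophen-2-yl in place of 4-methylphenyl gives an at least 3.3-fold higher number from compound 3 to compound 4 (0.52 log units; beyond the scatter), while adding hexyl to the saturated chain of the thiophen-2-yl compound gives an at least 10-fold higher number from compound 2 to compound 4 (1.01 log units; beyond the scatter), so the sulfonyl change did not carry over unchanged from the core of compound 1 to the core of compound 3: the same change on two cores in this assay, a 1.6-fold lower number (0.21 log units; within the scatter) from compound 1 to compound 2 and an at least 3.3-fold higher number (0.52 log units; beyond the scatter) from compound 3 to compound 4, at least 5.4-fold (0.73 log units) apart, beyond the scatter of two such steps The result does not show how large the step on the core of compound 3 really is, as only a bound on it exists, and this single pair of cores does not show what lies behind the difference.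

The compounds shown leave open how the same change would behave on a shorter or intermediate chain on the amide-type nitrogen. They also leave open whether another group on the sulfonyl sulfur, such as furan-2-yl, would follow thiophen-2-yl on the core of compound 3.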